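The source may report more compounds than this note shows. Statements on the series, on what has been measured and on what is new or still open speak of the compounds shown alone.

Three compounds measured so far in an ADME assay on Caco-2 cells (Homo sapiens) for permeability, read by LC-MS, in the apical to basolateral direction, with a stated time of 60 min, at pH 6.5; a higher number here means that the compound crosses the layer faster, a lower number that the compound crosses the layer more slowly
- Compound 1 `Cc1cccc([C@@H](O)C(=O)N2N=CC[C@H]2C(=O)NCc2cc(Cl)ccc2-n2cnnn2)c1` gives 9.7 10^-6 cm/s
- Compound 2 `CC1(C[C@@H](O)C(=O)N2N=CC[C@H]2C(=O)NCc2cc(Cl)ccc2-n2cnnn2)CC1` gives 9.5 10^-6 cm/s
- Compound 3 `CCCC[C@@H](O)C(=O)N1N=CC[C@H]1C(=O)NCc1cc(Cl)ccc1-n1cnnn1` gives 9.8 10^-6 cm/s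

On these numbers, compound 3 cannot be told apart from compound 1 or compound 2, as all three lie within the scatter of each other. Compound 4 `COC(C)(C)[C@@H](O)C(=O)N1N=CC[C@H]1C(=O)NCc1cc(Cl)ccc1-n1cnnn1` carries 1-methoxy-1-methylethyl in place of butyl on a saturated chain carbon bound to a carbonyl carbon and an oxygen on a saturated carbon. Swaps of this group have moved little so far: the steps are a 1.0-fold lower number from compound 1 to compound 2 (0.01 log units; within the scatter) and a 1.0-fold higher number from compound 1 to compound 3 (0.00 log units; within the scatter) and a 1.0-fold higher number from compound 2 to compound 3 (0.01 log units; within the scatter) and each lies within the scatter. None of those groups holds an oxygen, so the data leave that addition untested. A small step, perhaps slightly downward and no larger than the scatter, is therefore expected in this assay and the estimated step is a 1.3-fold lower number from compound 3 to compound 4 (0.12 log units; within the scatter) on this reasoning. For compound 4 the expected value is 7.5 10^-6 cm/s with an estimated range of 4 10^-6 cm/s to 12 10^-6 cm/s on this reasoning.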

Compound 4, apparent permeability: 1.7 10^-6 cm/s
For compound 4 the middle estimate is 4.4-fold (0.64 log units) above the measured one; the measured number lies below the stated range.
By their numbers in this assay, from the lowest: compound 4; then compounds 2, 1 and 3 (each within the scatter of the next).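

Up to now, 3-methylphenyl, (1-methylcyclopropyl)methyl and butyl at this position could not be told apart in this assay. So the position is not indifferent to every group: 1-methoxy-1-methylethyl, the only group here with an oxygen and a hydrogen-bond acceptor, gives a 5.8-fold lower number from compound 3 to compound 4 (0.76 log units; beyond the scatter), a 5.6-fold lower number from compound 2 to compound 4 (0.75 log units; beyond the scatter) and a 5.7-fold lower number from compound 1 to compound 4 (0.76 log units; beyond the scatter). No measurement shown accounts for this loss. The oxygen and the branched carbon skeleton enter together, so their shares remain unseparated. A tert-butyl group, which has no oxygen, or a straight methoxypropyl chain, which keeps the oxygen without the branching, would pull them apart.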